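Compound 3 to compound 4: a diamine chain replaces hydroxy

The source may hold more compounds than are shown below. What is called first, only, known or untested is meant among the compounds shown, and "the series" means these compounds.

In a functional assay on B16-F10 cells (Mus musculus) for antiproliferative activity, read by CCK-8 assay, with a stated time of 48 h (a lower number here means a stronger inhibitor, a higher number a weaker inhibitor), compound 1 (`COc1ccc(/C=C\c2cc(OC)c(OC)c(OC)c2)cc1OCc1ccc(C=O)cc1`) gives 4200 nM and compound 3 (`COc1ccc(/C=C\c2cc(OC)c(OC)c(OC)c2)cc1OCc1ccc(CO)cc1`) gives 6600 nM on the shared core. These two values lie within the scatter of each other (a 1.6-fold higher number from compound 1 to compound 3 (0.20 log units; within the scatter)), so compound 3 stands level with compound 1. For compound 2 (`COc1ccc(/C=C\c2cc(OC)c(OC)c(OC)c2)cc1OCc1ccc(CN2CCCC[C@H]2C(=O)O)cc1`) the read-out is only a limit (> 10000 nM).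

Compound 4 (`COc1ccc(/C=C\c2cc(OC)c(OC)c(OC)c2)cc1OCc1ccc(CNCCN(C)C)cc1`) keeps the core of compound 3 and carries (2-(dimethylamino)ethyl)amino in place of hydroxy on a saturated chain carbon bound to an aromatic carbon. The nearest guide is compound 2, which has 2-carboxypiperidin-1-yl on that same carbon. Its step to the hydroxy group (an at least 1.5-fold lower number from compound 2 to compound 3 (0.18 log units; that floor lies within the scatter)) has a floor within the scatter, whereas the step from formyl (an at least 2.3-fold higher number from compound 1 to compound 2 (0.37 log units; beyond the scatter)) goes beyond it. Only the second step shows a loss, and it rests on a group unlike the incoming chain, so it transfers weakly to compound 4.

In this assay, from the compounds shown here alone, no change beyond the scatter is therefore expected, and the direction stays open. The expected step (a 1.2-fold lower number from compound 3 to compound 4 (0.08 log units; within the scatter)) reflects this. Compound 4 is estimated at 5500 nM (expected range 2000 nM to 12000 nM).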

Compound 4, half-maximal inhibitory concentration: > 10000 nM
Compound 4: no number, only a limit; the forecaster's own chance of this, stated with the estimate: 15%; at least 1.8-fold (0.25 log units) between middle value and limit.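

In this assay, the (2-(dimethylamino)ethyl)amino chain on this saturated chain carbon gives an at least 1.5-fold higher number from compound 3 to compound 4 (0.18 log units; that floor lies within the scatter), so no loss beyond the scatter is established against hydroxy, although the true number may lie further off. Against formyl, the same change cut one bond further out gives an at least 2.3-fold higher number from compound 1 to compound 4 (0.37 log units; beyond the scatter); this makes the diamine chain, after the 2-carboxypiperidin-1-yl group of compound 2, a second large group at this place whose step from compound 1 goes beyond the scatter. The step between compound 2 and compound 4 cannot be read, and the size of all steps to these two compounds stays unresolved because the read-out ends at a limit: the limit of > 10000 nM in this assay, at which 2 of the 4 values shown sit.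

The compounds shown leave open whether a small primary amine, a morpholine ring or a simple carboxylic acid on this carbon would stand level with compound 1 and compound 3. They also do not separate the effect of the amine nitrogen from that of chain length, which a shorter or longer chain ending in the same dimethylamino group could test.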